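This account rests on a few compounds, and the source may have more. Where it says the series, first, only, none or still open, it means among the compounds named here.

Compound 1 `CN1CCc2nc(C#Cc3ccccc3)sc2C1` gives 34 nM in an assay on HEK293 cells for positive allosteric modulation of metabotropic glutamate receptor 5 (Homo sapiens), read by FLIPR, with a stated time of 1 h; a higher number here means that more compound is needed for the effect, a lower number that less compound is needed. Compound 2 `CN1CCc2nc(C#Cc3cccc(F)c3)sc2C1` returns in this assay only a limit of the assay, > 10000 nM. The step of an at least 290-fold higher number from compound 1 to compound 2 (2.46 log units; beyond the scatter) therefore ends at the limit of > 10000 nM in this assay, at which 1 of the 2 values shown sits. Compound 3 `Fc1cccc(C#Cc2nc3c(s2)CN(C2CCOC2)CC3)c1` differs from compound 2 by oxolan-3-yl in place of methyl on an amine nitrogen in a ring. For the measured compounds named here, the single measured step concerns a fluoro on an aromatic carbon, not the amine substituent, so it offers no direct guide to this change. Compound 3 is expected to remain near the limit, with an estimated 15000 nM lying between 3000 nM and 50000 nM. The expected step that the limit leaves unreadable from compound 2 to compound 3 is thus none beyond the scatter.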

Compound 3, half-maximal effective concentration: > 10000 nM
Compound 3 was reported as a limit; the forecaster's own chance of this, stated with the estimate: 70%; the middle value is on the limit's open side.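

In this assay compound 3 gives > 10000 nM as a limit of the assay. For the compounds shown here, compound 2 also stands at a limit, so no step from compound 2 to compound 3 can be read. As far as these compounds go, what oxolan-3-yl in place of methyl does to the number stays open.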